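The source may report more compounds than this note shows. Statements on the series, on what has been measured and on what is new or still open speak of the compounds shown alone.

Going by the values given here, compound 2 `COc1cc(C(=O)N2CCC(O)C(C)C2)cc2nc(NCc3cccc(Cl)c3)oc12` gives the lowest number of the two measured so far in an assay on isolated protein for inhibition of thyroid hormone receptor beta (Homo sapiens), read by fluorescence, with a stated time of 30 min; a higher number here means a weaker inhibitor, a lower number a stronger inhibitor: compound 2 gives 25 nM, while compound 1 `COc1cc(C(=O)N2CCC(O)CC2)cc2nc(NCc3cccc(Cl)c3)oc12` gives 352 nM. Among the compounds with values here, the only measured step, a 14-fold lower number from compound 1 to compound 2 (1.15 log units; beyond the scatter), concerns a methyl on a saturated ring and does not bear on the change now considered. Compound 3 `COc1cc(C(=O)N2CCC(O)C(C)C2)cc2nc(NCc3cncc(Cl)c3)oc12` differs from compound 2 by 5-chloropyridin-3-yl in place of 3-chlorophenyl on a saturated chain carbon bound to a nitrogen on an aromatic ring. Within the data shown here, with no measured step for such a change, no shift beyond the scatter is expected, so for compound 3 the estimate is 40 nM, between 12 nM and 130 nM, an expected step of a 1.6-fold higher number from compound 2 to compound 3 (0.20 log units; within the scatter).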

Compound 3, half-maximal inhibitory concentration: 7200 nM
For compound 3 the middle estimate is 180-fold (2.26 log units) below the measured one, outside the stated range (above it).
By their numbers in this assay, from the lowest: compound 2; then compound 1; then compound 3.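

Replacing 3-chlorophenyl with 5-chloropyridin-3-yl keeps the count of heavy atoms and exchanges just one ring carbon for a nitrogen, yet the result is a 290-fold higher number from compound 2 to compound 3 (2.46 log units; beyond the scatter). At this place, on a saturated chain carbon bound to a nitrogen on an aromatic ring, the two rings are therefore far from interchangeable. Nothing available explains this loss. Going by these compounds, it remains open how a plain phenyl, a fluorophenyl or a thiophene ring would fare here. Also open, on these data alone, is whether 5-chloropyridin-3-yl would cost as much on compound 1, which lacks the ring methyl.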